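Swapping a Bromophenyl for a Methoxyphenyl on a Shared Core

The compounds below may be only part of what the source reports. "The series", "measured", "known", "first", "only" and "open" are said of these compounds alone.

Of the compounds shown here, three sharing one core have been tested in a functional assay on UO-31 cells (Homo sapiens) for inhibition, read by sulforhodamine B assay, with a stated time of 48 h, tested at 10 uM; on this read-out higher numbers stand for more inhibition at the one concentration tested (going by the name of the read-out) and lower numbers for less inhibition. Compound 1 `c1ccc2c(-c3cn4ccnc4c(-c4ccc5ncn(C6CCCCC6)c5c4)n3)cccc2c1` carries a naphthalen-1-yl group, and in this assay compound 1 gives 23%. Compound 2 `Fc1ccc(-c2cn3ccnc3c(-c3ccc4ncn(C5CCCCC5)c4c3)n2)cc1` gives 37.8%, and compound 3 `Brc1ccc(-c2cn3ccnc3c(-c3ccc4ncn(C5CCCCC5)c4c3)n2)cc1` gives 42.9%, the highest of the three numbers; its gap to compound 2 lies within the scatter, while its gap to compound 1 lies beyond it. The two steps away from compound 1 were a number 14.8 percentage points higher from compound 1 to compound 2 (beyond the scatter) and a number 19.9 percentage points higher from compound 1 to compound 3 (beyond the scatter); the step between the two halogens, a number 5.1 percentage points higher from compound 2 to compound 3 (within the scatter), stayed within the scatter.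

Compound 4 `COc1ccccc1-c1cn2ccnc2c(-c2ccc3ncn(C4CCCCC4)c3c2)n1` differs from compound 3 by 2-methoxyphenyl in place of 4-bromophenyl on an aromatic carbon. Going by the values given here, no measured step compares a 2-methoxyphenyl with either 4-fluorophenyl or 4-bromophenyl, so nothing directly tells what this change does. Among the compounds with values here, the only step between two phenyl groups, a number 5.1 percentage points higher from compound 2 to compound 3 (within the scatter), was small, which suggests a small change here too. The estimated step is a number 7.9 percentage points lower from compound 3 to compound 4 (within the scatter), leaning slightly downward but within the scatter. Compound 4 is estimated at 35%, between 15% and 55%.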

Compound 4, a percentage reported as inhibition, at one concentration (the size of the read-out at that concentration, not a potency): 24%
Compound 4: the middle estimate sits 11 percentage points above what was measured, within the range that was stated.
By their numbers in this assay, from the lowest: compounds 1 and 4 (each within the scatter of the next); then compounds 2 and 3 (each within the scatter of the next).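

In this assay, the group at this position on the shared core clearly matters: 2-methoxyphenyl in place of the halogen-bearing phenyl groups gives a number 18.9 percentage points lower from compound 3 to compound 4 (beyond the scatter) and a number 13.8 percentage points lower from compound 2 to compound 4 (beyond the scatter), both beyond the scatter, whereas the earlier swap of one halogen for the other had stayed within it. The new compound also cannot be told apart from the naphthalen-1-yl compound, with a number 1 percentage points higher from compound 1 to compound 4 (within the scatter) lying within the scatter, so among the groups shown, only 4-fluorophenyl and 4-bromophenyl reach the higher numbers. Nothing available explains this difference.

Compound 4 differs from compound 2 and compound 3 both in the group on the phenyl ring and in where that group sits, and the compounds shown do not separate these two changes. As far as these compounds go, whether an amine or a carboxylic acid on that phenyl ring would reach the same numbers also remains open.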